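Replacing trifluoromethyl with carboxymethyl on the aromatic ring

The source may hold more compounds than are shown below. What is called first, only, known or untested is meant among the compounds shown, and "the series" means these compounds.

Measured so far in a functional assay on the whole organism for inhibition, with Rattus norvegicus as the target; a lower number here means that less compound is needed, a higher number that more compound is needed for the effect:
compound 1, `CC1CC/C(=N\Nc2ccccc2)c2ncc(CC(=O)O)c(=O)n21`, gives 100 umol/kg
compound 2, `CC1CC/C(=N\Nc2ccc(Br)cc2)c2ncc(C(=O)O)c(=O)n21`, gives 0.8 umol/kg
compound 3, `CC1CC/C(=N\Nc2ccc(C(F)(F)F)cc2)c2ncc(C(=O)O)c(=O)n21`, gives 38.6 umol/kg

Compound 3 stands second highest of these three numbers. Its nearest neighbour is compound 1, whose number is higher by a difference beyond the scatter, while compound 2 lies far below it.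

The next compound, compound 4, is `CC1CC/C(=N\Nc2ccc(CC(=O)O)cc2)c2ncc(C(=O)O)c(=O)n21`. It differs from compound 3 in a single place: carboxymethyl in place of trifluoromethyl on an aromatic carbon

Within the data shown here, only one measured step speaks to this place on the ring, a 48-fold higher number from compound 2 to compound 3 (1.68 log units; beyond the scatter). Among the measured compounds shown here, that step shows that exchanging the group here can move the number a great deal, but none of the measured compounds carries carboxymethyl on this ring, so the direction of the new change is not anchored by any measurement. Compound 1 carries a carboxymethyl elsewhere and also lacks the carboxyl group of the shared core, so its two differences from compound 3 cannot be separated.

With no direct guide, compound 4 is expected to stay in the region of compound 3, giving an estimated 25 umol/kg with a wide range from 3 umol/kg to 200 umol/kg. The expected step is a 1.5-fold lower number from compound 3 to compound 4 (0.19 log units; within the scatter), with no firm direction.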

Compound 4, dose for 50% inhibition: 60.9 umol/kg
For compound 4 the middle estimate is 2.4-fold (0.39 log units) below the measured one; the measured number falls inside the stated range.
By their numbers in this assay, from the lowest: compound 2; then compounds 3, 4 and 1 (each within the scatter of the next, the first and the last beyond it).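

In this assay the step is a 1.6-fold higher number from compound 3 to compound 4 (0.20 log units; within the scatter), so exchanging trifluoromethyl for carboxymethyl, which brings a hydrogen-bond donor and a hydrogen-bond acceptor to this place on the ring, gives two numbers that cannot be told apart. Bromo now stands alone among the three groups seen here, with a 76-fold higher number from compound 2 to compound 4 (1.88 log units; beyond the scatter) alongside the earlier 48-fold higher number from compound 2 to compound 3 (1.68 log units; beyond the scatter), and these two large steps show that both trifluoromethyl and carboxymethyl go with a much higher number than bromo on this ring. No measurement on these compounds accounts for that gap.

As far as these compounds go, whether the low number belongs to bromo alone stays open, since chloro, fluoro or a plain hydrogen at this place could show if other small groups keep it. Also open, from the compounds shown here alone, is whether a carboxylic acid attached directly to the ring, or a longer chain ending in one, would stay with compound 3 and compound 4 or move the number away from them.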